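A few compounds are considered here, and "the series" means these few. Any claim that something is new, unique, unknown or untested is made for them only; others in the source may bear on it.

Measured in a functional assay on MCF-A cells (Homo sapiens) for cytotoxicity; a lower number here means a stronger inhibitor of growth, a higher number a weaker inhibitor of growth:
- Compound 1 `COc1ccc(C2=C(c3ccc(SC)cc3)CC3CCCN3C2=O)cc1`: 5000 nM
- Compound 2 `CSc1ccc(C2=C(c3ccc(O)cc3)C(=O)N3CCCC3C2)cc1`: > 100000 nM

Compound 2 stands at the limit of > 100000 nM in this assay, at which 1 of the 2 values shown sits, and its entry is a limit, not a number. Compound 3 `CSc1ccc(C2=C(c3ccc(SC)cc3)C(=O)N3CCCC3C2)cc1` carries methylsulfanyl in place of hydroxy on an aromatic carbon. Among the compounds with values here, one measured step bears on this: an at least 20-fold higher number from compound 1 to compound 2 (1.30 log units; beyond the scatter), a large rise on hydrogen in place of methyl on an oxygen on an aromatic ring. Compound 3 also loses the hydroxy, so a large step to a lower number is expected, towards the value of compound 1 at 5000 nM. The estimated step is an at least 16-fold lower number from compound 2 to compound 3 (1.22 log units; beyond the scatter). The expected value for compound 3 is 6000 nM, with an estimated range of 1000 nM to 40000 nM.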

Compound 3, concentration for 50% growth inhibition: 8000 nM
Compound 3: middle estimate off by 1.3-fold (0.12 log units), on the low side; the range from low to high includes it.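

In this assay, methylsulfanyl in place of hydroxy on the aromatic carbon gives an at least 12-fold lower number from compound 2 to compound 3 (1.09 log units; beyond the scatter), so a second group besides methoxy is now seen to differ from hydroxy at this position. Compound 2 is a limit, not a number: the limit of > 100000 nM in this assay, at which 1 of the 3 values shown sits.

Methylsulfanyl in place of methoxy gives a 1.6-fold higher number from compound 1 to compound 3 (0.20 log units; within the scatter), so these two groups are not told apart at this position. Open, from the compounds shown here alone, is how an amine, a carboxylic acid or a longer chain would read here, and whether hydroxy alone stands apart.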